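A few compounds are considered here, and "the series" means these few. Any claim that something is new, unique, unknown or untested is made for them only; others in the source may bear on it.

Working notes on the series in an assay on microsomes from liver for inhibition of 3-hydroxy-3-methylglutaryl-coenzyme A reductase (Sus scrofa), read by colorimetric assay; on this read-out higher numbers stand for weaker inhibition and lower numbers for stronger inhibition.

Within the data shown here, compound 3 `CC(C)=CCC/C(C)=C/CCC1=C[C@H](c2ccc(C(C)(C)C)cc2)OC1=O` gives 5820 nM, the lowest number of the three measured so far. Among the measured compounds shown here, the parent compound 1 `CC(C)=CCC/C(C)=C/CCC1=C[C@H](c2ccccc2)OC1=O` gives 16500 nM, and the step of a 2.8-fold lower number from compound 1 to compound 3 (0.45 log units; beyond the scatter) is the only change on this ring that moved the read-out beyond the scatter. Compound 2 `CC(C)=CCC/C(C)=C/CCC1=C[C@H](c2ccccc2[N+](=O)[O-])OC1=O` gives 18900 nM; the step of a 1.1-fold higher number from compound 1 to compound 2 (0.06 log units; within the scatter) shows a nitro group at that position leaving the number where it was.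

Compound 4 `COc1ccc([C@H]2C=C(CC/C=C(\C)CCC=C(C)C)C(=O)O2)cc1` differs from compound 3 in one place: methoxy in place of tert-butyl on an aromatic carbon. For the measured compounds named here, no measured step involves a methoxy group, so the only guide is the modest gain seen for tert-butyl in a 2.8-fold lower number from compound 1 to compound 3 (0.45 log units; beyond the scatter) against the flat result for nitro in a 1.1-fold higher number from compound 1 to compound 2 (0.06 log units; within the scatter). A methoxy group is smaller than the tert-butyl it replaces, so part of that gain is expected to be given back, placing compound 4 between compound 3 and compound 1 rather than beyond either.

Compound 4 is therefore expected to give about 10000 nM in this assay, within 4000 nM to 25000 nM, a step of a 1.7-fold higher number from compound 3 to compound 4 (0.24 log units; within the scatter) from compound 3.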

Compound 4, half-maximal inhibitory concentration: 6210 nM
For compound 4 the middle estimate is 1.6-fold (0.21 log units) above the measured one, within the range that was stated.
By their numbers in this assay, from the lowest: compounds 3 and 4 (each within the scatter of the next); then compounds 1 and 2 (each within the scatter of the next).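

The exchange of tert-butyl for methoxy, a 1.1-fold higher number from compound 3 to compound 4 (0.03 log units; within the scatter) in this assay, shows that this place on the ring tolerates a group with fewer heavy atoms and a hydrogen-bond acceptor without a change beyond the scatter. Against the parent, a 2.7-fold lower number from compound 1 to compound 4 (0.42 log units; beyond the scatter) shows that the gain is not confined to tert-butyl, although the nitro group of compound 2 goes against any general gain from substitution of this ring, with a 1.1-fold higher number from compound 1 to compound 2 (0.06 log units; within the scatter) as its step. Nothing on hand explains why methoxy and tert-butyl read alike here.

Open, going by these compounds, is whether a hydroxyl, an amine or a carboxylic acid at this place would hold the number of compound 4. A longer chain such as butoxy, or a halogen such as chlorine, also remains to be placed against these two groups.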